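The compounds below may be only part of what the source reports. "The series", "measured", "known", "first", "only" and "open" are said of these compounds alone.

The measured compounds:
compound 1, `CCC(=O)c1ccc(OCCCCOc2cc(C(=O)O)ccc2OC)c(C)c1O`, 72.6%
compound 2, `COc1ccc(C(=O)O)cc1OCCCCOc1ccc(C(C)=O)c(O)c1C`, 70.7%
compound 3, `COc1cc(C(=O)O)ccc1OCCCCOc1ccc(C(C)=O)c(O)c1C`, 86.3%

The three compounds were tested in an assay on HEK293 cells for positive allosteric modulation of metabotropic glutamate receptor 2 (Rattus norvegicus), read by thallium flux, with a stated time of 2.5 min; a higher number here means a larger maximal response, a lower number a smaller maximal response. Compound 2 and compound 1 differ in one place, (methyl in place of hydrogen on a saturated chain carbon bound to a carbonyl carbon), and that change made a step of a number 1.9 percentage points higher from compound 2 to compound 1 (within the scatter). Compound 3 and compound 2 are built from the same atoms joined differently; the difference between the two cores is not broken down here. Of the three, compound 3 reached the largest maximal response: compound 3 gives 86.3%, while compound 1 gives 72.6% and compound 2 gives 70.7%, both gaps lying beyond the scatter.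

Compound 4, `CCC(=O)c1ccc(OCCCCOc2ccc(C(=O)O)cc2OC)c(C)c1O`, has not yet been measured in this assay. It differs from compound 3 by methyl in place of hydrogen on a saturated chain carbon bound to a carbonyl carbon, and this is the same change as the one from compound 2 to compound 1, at the same place in both pairs; it occurs twice among the compounds shown. Within the data shown here, since the one measured instance of this change gave a number 1.9 percentage points higher from compound 2 to compound 1 (within the scatter), which lies within the scatter, the account expects a step of about a number 0.7 percentage points higher from compound 3 to compound 4 (within the scatter) for compound 4 as well, resting on that single earlier step and on the value of compound 3. Compound 4 is therefore expected to give about 87% in this assay. The expected range for compound 4 runs from 75% to 99%.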

Compound 4, largest response reached (reported as percent of maximum), in percent of the reference or control that the assay uses: 86.5%
Estimate against measurement, compound 4: 0.5 percentage points above; low and high end bracket the measured number.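

In this assay, the change from acetyl to propanoyl, methyl in place of hydrogen on a saturated chain carbon bound to a carbonyl carbon, gave a step of a number 0.2 percentage points higher from compound 3 to compound 4 (within the scatter). Across the two cores the change behaves alike, so in this series it can be carried from one core to the other with no step beyond the scatter and no detectable difference between the two steps: the same change on two cores in this assay, a number 1.9 percentage points higher (within the scatter) from compound 2 to compound 1 and a number 0.2 percentage points higher (within the scatter) from compound 3 to compound 4, 1.7 percentage points apart, within the scatter of two such steps This rests on only two pairs, and since neither step stands out from the scatter, it shows that the change leaves the maximal response about where it was on these two cores, not that it would do so on a further core, nor that any small real effect is the same on both.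

The compounds shown leave open whether a still longer chain at the carbonyl, such as butanoyl, or a branched one, such as isobutyryl, would also leave the maximal response in place. They also leave open what an amide or a tetrazole in place of the carboxylic acid would do, and whether the acetyl and propanoyl groups would still match on a core carrying such a group.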